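The compounds below may be only part of what the source reports. "The series", "measured", "known", "first", "only" and "open" are said of these compounds alone.

Compound 1 `CS(=O)(=O)Nc1cccc(-c2ccc(COC3CC[C@H](N4CCCCCC4)[C@H]3OC/C=C\CCC(=O)O)cc2)c1` holds the lower of the two numbers in a functional assay on blood for antagonist activity at thromboxane A2 receptor (Homo sapiens) (on this read-out lower numbers stand for tighter binding and higher numbers for weaker binding), at 12.6 nM, while compound 2 `O=C(O)CC/C=C\CO[C@@H]1C(OCc2ccc(-c3ccccc3)cc2)CC[C@@H]1N1CCCCC1` gives 39.8 nM, a gap beyond the usual scatter. Compound 3 `NC(=O)c1ccccc1-c1ccc(COC2CC[C@H](N3CCCCCC3)[C@H]2OC/C=C\CCC(=O)O)cc1` is not yet measured; it differs from compound 1 by 2-carbamoylphenyl in place of 3-(methanesulfonamido)phenyl on an aromatic carbon. For the measured compounds named here, no step between measured compounds covers this change, so the expectation rests on compound 1 alone. Compound 3 is expected to move by a 2.0-fold higher number from compound 1 to compound 3 (0.30 log units; within the scatter), a small step toward a weaker number that may still sit within the scatter. The estimate for compound 3 is 25 nM, between 8 nM and 80 nM.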

Compound 3, dissociation constant: 15.9 nM
Compound 3: middle estimate off by 1.6-fold (0.20 log units), on the high side; low and high end bracket the measured number.
By their numbers in this assay, from the lowest: compounds 1 and 3 (each within the scatter of the next); then compound 2.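

In this assay, the step with 2-carbamoylphenyl in place of 3-(methanesulfonamido)phenyl, on an aromatic carbon para to a large group, is a 1.3-fold higher number from compound 1 to compound 3 (0.10 log units; within the scatter). For the compounds shown here, the two groups therefore cannot be told apart on this read-out, and the methanesulfonamido group is not the only group at this place that gives a number in this range. Nothing measured here explains this result. As far as these compounds go, it remains open whether a nitrile or an aminomethyl group in place of the carbamoyl group would give a number in the same range.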